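The source may hold more compounds than are shown below. What is called first, only, known or untested is meant among the compounds shown, and "the series" means these compounds.

In a functional assay on SGC-7901 cells (Homo sapiens) for antiproliferative activity, read by MTT assay, with a stated time of 72 h (a lower number here means a stronger inhibitor, a higher number a weaker inhibitor), compound 1 `COc1cc(-n2cnc3ccc(-c4ccc(C(F)(F)F)cc4)cc32)cc(OC)c1OC` gives 890 nM. Compound 2 `COc1cc(-n2cnc3ccc(-c4ccc(Cl)cc4Cl)cc32)cc(OC)c1OC` stands at > 10000 nM, which is a limit and not a number. Compound 3 `COc1cc(-n2cnc3ccc(-c4ccc(F)cc4)cc32)cc(OC)c1OC` differs from compound 2 by 4-fluorophenyl in place of 2,4-dichlorophenyl on an aromatic carbon, with 4-fluorophenyl in place of 2,4-dichlorophenyl on an aromatic carbon. Within the data shown here, the only measured step bearing on this is an at least 11-fold higher number from compound 1 to compound 2 (1.05 log units; beyond the scatter), where 2,4-dichlorophenyl entered in place of 4-(trifluoromethyl)phenyl. Losing 2,4-dichlorophenyl is therefore expected to give a large step to a lower number in this assay, estimated as an at least 6.6-fold lower number from compound 2 to compound 3 (0.82 log units; beyond the scatter). For compound 3 the estimated value is 1500 nM, with a range of 300 nM to 8000 nM.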

Compound 3, half-maximal inhibitory concentration: 3500 nM
Beside the measured number, compound 3's estimate is 2.3-fold (0.37 log units) below it; low and high end bracket the measured number.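

In this assay, 4-fluorophenyl brings back a measurable value at this position, with an at least 2.8-fold lower number from compound 2 to compound 3 (0.45 log units; beyond the scatter). Compound 2 stands at a limit and not a number, so that step has only a bound: the limit of > 10000 nM in this assay, at which 1 of the 3 values shown sits. The change confined to the single phenyl substituent, fluoro in place of trifluoromethyl, also costs activity, with a 3.9-fold higher number from compound 1 to compound 3 (0.59 log units; beyond the scatter).

Open, from the compounds shown here alone, is where 4-chlorophenyl, carrying a single chlorine, would fall, which would help separate the contributions of the two chlorines of compound 2. Also open, going by these compounds, is how an amine or a carboxylic acid on that phenyl ring would read.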